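This account rests on a few compounds, and the source may have more. Where it says the series, first, only, none or still open, it means among the compounds named here.

In a functional assay on U-251 cells (Homo sapiens) for inhibition, read by sulforhodamine B assay, with a stated time of 48 h (a higher number here means a weaker inhibitor of growth, a lower number a stronger inhibitor of growth), compound 2 `COc1cc(-c2nn(-c3cccc(NC(=O)c4cccc(C(F)(F)F)c4)c3)cc2-c2ccncc2)ccc1Cl` gives > 50000 nM, which is a limit of the assay and not a number. Compound 1 `COc1cc(-c2nn(-c3cccc(NC(=O)c4ccc(Cl)c(C(F)(F)F)c4)c3)cc2-c2ccncc2)ccc1Cl` gives > 32500 nM in this assay, likewise a limit. The step that the two limits leave unreadable from compound 1 to compound 2 cannot be sized because both ends sit at the limit of > 32500 nM in this assay, at which 1 of the 3 values shown sits, and (the limit of > 50000 nM in this assay, at which 1 of the 3 values shown sits). Within the data shown here, compound 3 `O=C(Nc1cccc(-n2cc(-c3ccncc3)c(-c3ccc(Cl)c(O)c3)n2)c1)Nc1cc(C(F)(F)F)cc(C(F)(F)F)c1` gives 1170 nM in this assay; no step connects it to compound 2, so only the two values stand side by side. Compound 4 `COc1cc(-c2nn(-c3cccc(NC(=O)Nc4cccc(C(F)(F)F)c4)c3)cc2-c2ccncc2)ccc1Cl` differs from compound 2 by (3-(trifluoromethyl)phenyl)amino in place of 3-(trifluoromethyl)phenyl on a carbonyl carbon; the entering linkage at the carbonyl carbon resembles that found in compound 3. Among the measured compounds shown here, no measured step bears directly on this change. Compound 4 is expected to give 8000 nM, between 1500 nM and 50000 nM, an estimated step of an at least 6.2-fold lower number from compound 2 to compound 4 (0.79 log units; beyond the scatter).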

Compound 4, concentration for total growth inhibition: 1370 nM
The estimate for compound 4 lay 5.8-fold (0.77 log units) above the measured number; measured number below the stated range.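

In this assay, (3-(trifluoromethyl)phenyl)amino in place of 3-(trifluoromethyl)phenyl on a carbonyl carbon gives an at least 36-fold lower number from compound 2 to compound 4 (1.56 log units; beyond the scatter), a minimum size, as the starting value is a limit of the assay: the limit of > 50000 nM in this assay, at which 1 of the 4 values shown sits.

Measured against 4-chloro-3-(trifluoromethyl)phenyl, the same entering group gives an at least 23-fold lower number from compound 1 to compound 4 (1.37 log units; beyond the scatter), again a minimum size starting from a limit of the assay: the limit of > 32500 nM in this assay, at which 1 of the 4 values shown sits.

Among these compounds, the step between the two limits cannot be read, so these are the first readable sizes at this position.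

Open, on these data alone, is whether a methylene or an oxygen linking the carbonyl carbon to the ring would give a similar step.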